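The source may report more compounds than this note shows. Statements on the series, on what has been measured and on what is new or still open speak of the compounds shown alone.

Measured compounds:
- Compound 1, `O=C(COc1ccc(C(=O)/C=C/c2ccc(Cl)cc2Cl)cc1)N[C@H]1CCOC1=O`: 8040 nM
- Compound 2, `O=C1OCC[C@@H]1NC(=S)SCCOc1ccc([N+](=O)[O-])cc1`: 32500 nM
- Compound 3, `CCCCCCCCCCSC(=S)N[C@H]1CCOC1=O`: limit, > 64000 nM

Three compounds sharing the lactone-bearing core were tested in a functional assay on PC-3 cells (Homo sapiens) for antiproliferative activity, read by MTT assay, with a stated time of 72 h; on this read-out lower numbers stand for stronger inhibition and higher numbers for weaker inhibition. Compound 1, the chalcone bearing a 2,4-dichlorophenyl group, gives 8040 nM, the lowest of the two numbers recorded. Compound 2, the nitrophenoxy dithiocarbamate, gives 32500 nM, a higher number that lies beyond the scatter of this assay. For compound 3, the decyl dithiocarbamate, only a limit is recorded, > 64000 nM; this is the limit of > 64000 nM in this assay, at which 1 of the 3 values shown sits.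

Compound 4, `CC(C)c1ccc(/C=C/C(=O)c2ccc(OCC(=O)N[C@H]3CCOC3=O)cc2)cc1`, has not yet been measured in this assay. It differs from compound 1 in a single place: 4-isopropylphenyl in place of 2,4-dichlorophenyl on a double-bonded chain carbon bound to a double-bonded chain carbon. Going by the values given here, no measured pair of compounds in this set shows the effect of a change of this kind on the chalcone arm, so the step can only be anticipated. Since both rings are carbon-only aromatic rings without donors or acceptors, a step of modest size is expected, most likely toward a somewhat higher number, and it may well fall within the scatter. Compound 4 is therefore estimated to give 12000 nM in this assay, with a plausible range from 4000 nM to 40000 nM, which corresponds to an expected step of a 1.5-fold higher number from compound 1 to compound 4 (0.17 log units; within the scatter).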

Compound 4, half-maximal inhibitory concentration: 4660 nM
Estimate against measurement, compound 4: 2.6-fold (0.41 log units) above; low and high end bracket the measured number.
By their numbers in this assay, from the lowest: compounds 4 and 1 (each within the scatter of the next); then compound 2. At a limit, above all of these: compound 3.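

In this assay, going by these compounds alone, 4-isopropylphenyl in place of 2,4-dichlorophenyl on a double-bonded chain carbon bound to a double-bonded chain carbon gives a 1.7-fold lower number from compound 1 to compound 4 (0.24 log units; within the scatter), the first step in this set that can be read between two compounds differing in one place. At this position, then, a group of nine carbon atoms can stand in for one of six carbon and two chlorine atoms without the two compounds being told apart on this read-out, so the chlorine atoms are not needed to keep the number in this range. No measurement shown here bears on why the exchange leaves the read-out so little changed.

On these data alone, both groups compared carry one six-membered aromatic ring of carbon only and neither has a hydrogen-bond donor or acceptor, so it remains open how this position would respond to a ring carrying an amine or a carboxylic acid. Within the data shown here, it also remains open whether a smaller unsubstituted phenyl or a longer alkyl chain on that ring would move the number beyond the scatter, as this single pair covers only one exchange.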